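The source may report more compounds than this note shows. Statements on the series, on what has been measured and on what is new or still open speak of the compounds shown alone.

Compound 1 `O=[N+]([O-])c1cccc(Nc2nc3ncccc3n2Cc2ccccc2)c1` and compound 2 `Cc1ccc(Nc2nc3ncccc3n2Cc2ccccc2)cc1[N+](=O)[O-]` share one core. In a functional assay on HCT-116 cells (Homo sapiens) for antiproliferative activity, read by MTT assay, with a stated time of 72 h (a higher number here means a weaker inhibitor of growth, a lower number a stronger inhibitor of growth), compound 1 gives 41700 nM, and compound 2 gives 40400 nM. The change between them, (methyl in place of hydrogen on an aromatic carbon), sits on an aromatic carbon of a six-membered aromatic ring of carbon only, ortho to a nitro group and para to a large group, and its step was a 1.0-fold lower number from compound 1 to compound 2 (0.01 log units; within the scatter). Compound 3 `NS(=O)(=O)c1cccc(Nc2nccc(-n3ncc4cccnc43)n2)c1` rests on a different core; the difference between the two cores is not broken down here. In this assay compound 3 gives 14600 nM, the lowest of the three numbers. Compound 4 `Cc1nn(-c2ccnc(Nc3cccc(S(N)(=O)=O)c3)n2)c2ncccc12` is not yet measured. It differs from compound 3 by methyl in place of hydrogen on an aromatic carbon, placed on an aromatic carbon of a five-membered aromatic ring with 2 nitrogen, part of a fused system of two rings, next to the ring nitrogen, so this is the same kind of change as that from compound 1 to compound 2, not the same one. Because the earlier step in this assay was a 1.0-fold lower number from compound 1 to compound 2 (0.01 log units; within the scatter), the step expected from compound 3 to compound 4 is a 1.0-fold lower number from compound 3 to compound 4 (0.02 log units; within the scatter). Compound 4 is thus estimated at 14000 nM, between 7000 nM and 28000 nM.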

Compound 4, concentration for 50% growth inhibition: 24800 nM
Compound 4: middle estimate off by 1.8-fold (0.25 log units), on the low side; the measured number falls inside the stated range.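

In this assay, methyl in place of hydrogen on an aromatic carbon of the five-membered aromatic ring gives a 1.7-fold higher number from compound 3 to compound 4 (0.23 log units; within the scatter), a step too small to read as a real effect. Set beside the earlier step, the result from this core cannot be told apart from the result on the core of compound 1: the same change on two cores in this assay, a 1.0-fold lower number (0.01 log units; within the scatter) from compound 1 to compound 2 and a 1.7-fold higher number (0.23 log units; within the scatter) from compound 3 to compound 4, 1.8-fold (0.24 log units) apart, within the scatter of two such steps This shows that, in these two pairs, the methyl left the number within the scatter on both cores, but it does not show a rule for other cores, since there are only two pairs, the methyl stands at a different place in each, and neither step is large enough to reveal a real effect that could carry across.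

The compounds shown leave open whether an ethyl group, an amine or a carboxylic acid on that same aromatic carbon would give a step beyond the scatter. They also leave open whether any such step would be of similar size on the core of compound 1.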